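Removing a trifluoromethyl group from compound 1

This account rests on a few compounds, and the source may have more. Where it says the series, first, only, none or still open, it means among the compounds named here.

- compound 1 `COc1cc(-c2nn(-c3cccc(NC(=O)c4cccc(C(F)(F)F)c4)c3)cc2-c2ccncc2)ccc1Cl`: 32100 nM
- compound 2 `COc1cc(-c2nn(-c3cccc(NC(=O)Nc4cccc(C(F)(F)F)c4)c3)cc2-c2ccncc2)ccc1Cl`: > 50000 nM (a limit of the assay, not a number)
- compound 3 `O=C(Nc1cccc(-n2cc(-c3ccncc3)c(-c3ccc(Cl)c(O)c3)n2)c1)Nc1cc(C(F)(F)F)cc(C(F)(F)F)c1`: 5620 nM

In a functional assay on DU-145 cells (Homo sapiens) for inhibition, read by sulforhodamine B assay, with a stated time of 48 h (a higher number here means a weaker inhibitor of growth, a lower number a stronger inhibitor of growth), compound 1 has the higher of the two actual numbers, and compound 3 has the lower. Compound 4 `COc1cc(-c2nn(-c3cccc(NC(=O)c4ccccc4)c3)cc2-c2ccncc2)ccc1Cl` differs from compound 1 by a single change: hydrogen in place of trifluoromethyl on an aromatic carbon. For the measured compounds named here, the only measured step, an at least 1.5-fold higher number from compound 1 to compound 2 (0.19 log units; that floor lies within the scatter), alters a different place, so it offers no direct guide to this change. Compound 1, at 32100 nM, is therefore the anchor, and no step beyond the scatter is expected in this assay, in either direction. The expected change is a 1.1-fold higher number from compound 1 to compound 4 (0.04 log units; within the scatter). Compound 4 is estimated at 35000 nM, with an expected range of 14000 nM to 50000 nM.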

Compound 4, concentration for total growth inhibition: 54700 nM
Estimate against measurement, compound 4: 1.6-fold (0.19 log units) below; measured number above the stated range.
By their numbers in this assay, from the lowest: compound 3; then compounds 1 and 4 (each within the scatter of the next).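

In this assay, for the compounds shown here, putting hydrogen in place of the trifluoromethyl group of compound 1 gives a 1.7-fold higher number from compound 1 to compound 4 (0.23 log units; within the scatter) and is the first direct reading of this position. In this pair, the trifluoromethyl group can go without a step beyond the scatter. The step between compound 2 and compound 4 cannot be read, because compound 2 carries a limit: the limit of > 50000 nM in this assay, at which 1 of the 4 values shown sits.

Going by these compounds, whether an amine or a carboxylic acid on this aromatic carbon would give a step beyond the scatter stays open. So does whether losing trifluoromethyl reads the same in the urea compounds.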